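Cyclopropylsulfonyl in place of acetyl on the pyrrolidine nitrogen

The compounds below may be only part of what the source reports. "The series", "measured", "known", "first", "only" and "open" are said of these compounds alone.

Compound 1, `CN1CCN(c2ccc(Nc3ncc4nc(Nc5ccccc5)n([C@H]5CCNC5)c4n3)cc2)CC1`: a functional assay on A549 cells (Homo sapiens) for antiproliferative activity, read by MTT assay, with a stated time of 72 h; on this read-out lower numbers stand for stronger inhibition and higher numbers for weaker inhibition "not determined" (no result reported).
Compound 2, `CN1CCN(c2ccc(Nc3ncc4nc(Nc5ccccc5)n([C@@H]5CCN(S(=O)(=O)C6CC6)C5)c4n3)cc2)CC1`: 2910 nM.
Compound 3, `CC(=O)N1CC[C@H](n2c(Nc3ccccc3)nc3cnc(Nc4ccc(N5CCN(C)CC5)cc4)nc32)C1`: "not determined" (no result reported).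
Compound 4, `CN1CCN(c2ccc(Nc3ncc4nc(Nc5ccccc5)n([C@H]5CCN(S(=O)(=O)C6CC6)C5)c4n3)cc2)CC1`: to be measured.

Compound 3 has no number of its own in this assay, and the same is true of compound 1, so compound 3 stands nowhere on the numbers shown; the only value in the series is that of compound 2, which gives 2910 nM. The change to compound 4 is cyclopropylsulfonyl in place of acetyl on an amine nitrogen in a ring. Among the measured compounds shown here, with no measured step between related pairs, the size and direction of this step cannot be read from the data, and the author expects only that compound 4 falls in the same broad region as compound 2. The estimate for compound 4 is 1500 nM, with an expected range from 300 nM to 8000 nM.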

Compound 4, half-maximal inhibitory concentration: 540 nM
Compound 4: middle estimate off by 2.8-fold (0.44 log units), on the high side, within the range that was stated.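

In this assay, the configuration at the saturated ring carbon bearing the large group matters when cyclopropylsulfonyl sits on the pyrrolidine nitrogen, with the drawn S form giving a 5.4-fold lower number from compound 2 to compound 4 (0.73 log units; beyond the scatter). Among the compounds shown here, this is the first readable step, and it isolates the stereocentre as the sole point of change: the fact that compounds 2 and 4 differ only in the configuration as drawn.

The step from acetyl to cyclopropylsulfonyl itself cannot be read. As far as these compounds go, whether the same configuration is favoured with a methanesulfonyl group or a longer alkyl chain on that nitrogen remains open.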